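Diethylamino in place of anilino on a fused pyrimidine-type core

A few compounds are considered here, and "the series" means these few. Any claim that something is new, unique, unknown or untested is made for them only; others in the source may bear on it.

Measured compounds so far:
compound 1, `Cc1nc(NC(C)C)c2cnn(-c3ccccc3)c2n1`: > 100000 nM (a limit of the assay)
compound 2, `CCCCNc1nc(C)nc2c1cnn2-c1ccccc1`: > 100000 nM (a limit of the assay)
compound 3, `Cc1nc(Nc2ccccc2)c2cnn(-c3ccccc3)c2n1`: > 100000 nM (a limit of the assay)

All three were tested in a functional assay on G-361 cells (Homo sapiens) for cytotoxicity, read by sulforhodamine B assay; a lower number here means a stronger inhibitor of growth, a higher number a weaker inhibitor of growth. Compound 1 gives only a limit there, > 100000 nM. Compound 2 likewise gives only a limit, > 100000 nM. Compound 3 also gives only a limit, > 100000 nM. Compound 3 therefore stands nowhere in particular among the numbers shown: it sits at the same limit as the other two, and none of the three can be ordered against the others.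

Compound 4, `CCN(CC)c1nc(C)nc2c1cnn2-c1ccccc1`, differs from compound 3 in one place: diethylamino in place of anilino on an aromatic carbon. Going by the values given here, the steps that bear on this change are a step that the two limits leave unreadable from compound 1 to compound 3 and a step that the two limits leave unreadable from compound 2 to compound 3, both of which swap one group on the same ring nitrogen, and both are unreadable, since every value involved sits at the limit of > 100000 nM in this assay, at which 3 of the 3 values shown sit. Among the compounds with values here, no measured step gives a direction or a size for swapping the group at this position in this assay.

With nothing beyond limits to go on, compound 4 is expected to behave like its neighbours and to give 150000 nM, with a range from 50000 nM to 500000 nM. That amounts to an expected step that the limit leaves unreadable from compound 3 to compound 4, which is no step beyond the scatter.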

Compound 4, concentration for total growth inhibition: > 100000 nM
Compound 4 ended at the assay's limit (the forecaster's own chance of this, stated with the estimate: 85%); the middle value is on the limit's open side.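

Compound 4 adds no readable step against compound 1, compound 2 or compound 3 in this assay, because all four values are limits of the assay and not numbers: the limit of > 100000 nM in this assay, at which 4 of the 4 values shown sit. The compounds shown leave open whether any of these groups on the shared core changes growth inhibition, and in which direction.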